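The compounds below may be only part of what the source reports. "The series", "measured", "known", "first", "only" and "open" are said of these compounds alone.

For the measured compounds named here, in a functional assay on V79 cells (Cricetulus griseus) for cytotoxicity, read by colony formation (a higher number here means a weaker inhibitor, a lower number a stronger inhibitor), only two compounds have numbers so far. Compound 1 (`NCC1CCN(c2c(F)cc3c(=O)c(C(=O)O)cn(C4CC4)c3c2Cl)C1`) gives 8 ug/mL. Compound 2 (`CC1(CN)CCN(c2cc3c(cc2F)c(=O)c(C(=O)O)cn3C2CC2)C1`) gives 23 ug/mL, the higher of the two numbers, which makes compound 2 the weaker inhibitor by a gap beyond the usual scatter. Compound 3 (`CC1(CN)CCN(c2c(F)cc3c(=O)c(C(=O)O)cn(C4CC4)c3c2Cl)C1`) is compound 2 with a single change, chloro in place of hydrogen on an aromatic carbon. Going by the values given here, no measured pair shows this change alone. Compound 1, at 8 ug/mL, carries chloro on that same carbon, but it also differs from compound 2 in its pyrrolidine group, so it is only a rough guide. The expected size of the change is a 2.1-fold lower number from compound 2 to compound 3 (0.32 log units; beyond the scatter), towards a lower number and a stronger inhibitor. For compound 3 the estimated value is 11 ug/mL, with an expected range from 4 ug/mL to 28 ug/mL.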

Compound 3, half-maximal inhibitory concentration: 8 ug/mL
For compound 3 the middle estimate is 1.4-fold (0.14 log units) above the measured one, within the range that was stated.
By their numbers in this assay, from the lowest: compounds 1 and 3 (each within the scatter of the next); then compound 2.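

Now seen on its own in this assay, chloro in place of hydrogen on this aromatic carbon, ortho to the 3-(aminomethyl)-3-methylpyrrolidin-1-yl group, gives a 2.9-fold lower number from compound 2 to compound 3 (0.46 log units; beyond the scatter) and so is a real, modest step towards a stronger inhibitor. Methyl in place of hydrogen on a saturated ring carbon, which was mixed up with the chloro change in the earlier comparison, gives no change at the digits printed from compound 1 to compound 3 (within the scatter) and so makes no visible difference when chloro is present. No measurement at hand explains the size of the chloro step.

As far as these compounds go, whether fluoro, methyl or methoxy on the same aromatic carbon would act as chloro does remains open. So does whether methyl on the saturated ring carbon would also make no visible difference with hydrogen on that aromatic carbon.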